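The source may hold more compounds than are shown below. What is called first, only, known or untested is meant among the compounds shown, and "the series" means these compounds.

Working notes on the series.

The three measured compounds share one core and differ in the ring substituent and the amide end. Compound 1 `NC(=O)/C=C1\CCc2cc(Cl)ccc21` carries the primary amide; in a functional assay on the whole organism with Rattus norvegicus as the target, at a dose of 20 mg/kg by the oral route (a higher number here means more inhibition at the dose given (going by the name of the read-out), a lower number less inhibition), compound 1 gives 30%. Compound 2 `O=C(/C=C1\CCc2ccc(F)cc21)NCCO` carries the (2-hydroxyethyl)amino amide; in this assay compound 2 gives 42%. Compound 3 `COc1ccc2c(c1)/C(=C/C(N)=O)CC2` carries the methoxy group on the ring, and in this assay compound 3 gives 1%.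

On these numbers compound 2 stands highest of the three. Its nearest neighbour is compound 1, lower by a gap beyond the scatter; compound 3 lies furthest, lower by a gap well beyond the scatter. Whether the ring substituent or the amide end drives the gaps cannot be separated: no two of the measured compounds differ in a single place.

Compound 4 `CON(C)C(=O)/C=C1\CCc2ccc(F)cc21` keeps the ring substituent of compound 2 and alters only the amide end: methoxy(methyl)amino in place of (2-hydroxyethyl)amino on a carbonyl carbon. The change removes the hydrogen-bond donors of the amide end while the acceptor count is unchanged. Within the data shown here, with no single-place step measured, the expectation for this assay rests on the spread among compounds 1, 2 and 3 alone. A moderate downward step is expected, a number 17 percentage points lower from compound 2 to compound 4 (beyond the scatter), since the two amide ends with a free amide hydrogen, compound 1 at 30% and compound 2 at 42%, both sit clearly above compound 3. Compound 4 is therefore estimated at 25%, in a range from 5% to 45%.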

Compound 4, a percentage reported as inhibition, in the whole organism at one dose (the size of the read-out at that dose, not a potency): 6%
For compound 4 the middle estimate is 19 percentage points above the measured one; low and high end bracket the measured number.
By their numbers in this assay, from the lowest: compounds 3 and 4 (each within the scatter of the next); then compound 1; then compound 2.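

Among these compounds, the series now has its first single-place step: with the ring substituent held and only methoxy(methyl)amino in place of (2-hydroxyethyl)amino on a carbonyl carbon, this assay gives a number 36 percentage points lower from compound 2 to compound 4 (beyond the scatter) (large), so the amide end alone can move this read-out by a wide margin, a point the earlier compounds could not separate from the ring substituent. The two groups hold the same count of 4 heavy atoms, made up of the same atoms joined differently, and the count that changes is that of hydrogen-bond donors, 2 in the group that leaves and 0 in the group that enters, though this single step cannot say whether that count or the arrangement of the atoms matters. Nothing available bears on why the number falls.

Open, from the compounds shown here alone, is where a dimethylamino group or a 2-methoxyethylamino group on the same carbonyl carbon would stand in this assay relative to compound 2 and compound 4. Also open, going by these compounds, is whether the same exchange of amide ends would give a step of similar size on the chloro or methoxy ring substituents of compound 1 and compound 3.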